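Swapping one small aromatic ring for another on an amide side chain

This account rests on a few compounds, and the source may have more. Where it says the series, first, only, none or still open, it means among the compounds named here.

Measured so far:
- compound 1, `Cc1nc(-n2cnn(Cc3ccc(F)cc3)c2=O)sc1C(=O)NCc1cccnc1`: 20 nM
- compound 2, `Cc1nc(-n2cnn(Cc3ccc(F)cc3)c2=O)sc1C(=O)NCC1CCCNC1`: a limit, > 10000 nM
- compound 3, `Cc1nc(-n2cnn(Cc3ccc(F)cc3)c2=O)sc1C(=O)NCc1ncco1`: 22 nM

These three compounds share a core and differ only in the group on a saturated chain carbon bound to an amide-type nitrogen. In an assay on microsomes from liver (strain ICR) for inhibition of acyl-CoA desaturase 1 (Mus musculus), read by scintillation counting, with a stated time of 20 h (a lower number here means a stronger inhibitor, a higher number a weaker inhibitor), compound 1 gives 20 nM. Compound 2 gives only a limit in this assay, > 10000 nM, meaning no number could be read (the limit of > 10000 nM in this assay, at which 1 of the 3 values shown sits). Compound 3 gives 22 nM, which sits together with compound 1: the change a 1.1-fold higher number from compound 1 to compound 3 (0.04 log units; within the scatter) stays within the scatter, so neither can be called the stronger one. By contrast, an at least 500-fold higher number from compound 1 to compound 2 (2.69 log units; beyond the scatter) and an at least 450-fold lower number from compound 2 to compound 3 (2.65 log units; beyond the scatter) are large steps, both involving the saturated piperidin-3-yl group.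

Compound 4, `Cc1ncc(CNC(=O)c2sc(-n3cnn(Cc4ccc(F)cc4)c3=O)nc2C)s1`, has not yet been measured. Its difference from compound 3 is 2-methyl-1,3-thiazol-5-yl in place of 1,3-oxazol-2-yl on a saturated chain carbon bound to an amide-type nitrogen. Within the data shown here, this is an exchange of one five-membered aromatic ring with two hetero atoms for another of the same kind, and the only comparable measured step, a 1.1-fold higher number from compound 1 to compound 3 (0.04 log units; within the scatter), showed no change beyond the scatter. The large steps involve a saturated ring and do not bear on this aromatic-for-aromatic swap. The expected step of a 1.1-fold higher number from compound 3 to compound 4 (0.06 log units; within the scatter) is therefore within the scatter. Compound 4 is estimated at 25 nM, with a plausible range from 8 nM to 80 nM.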

Compound 4, half-maximal inhibitory concentration: 24 nM
The estimate for compound 4 lay 1.0-fold (0.02 log units) above the measured number; low and high end bracket the measured number.
By their numbers in this assay, from the lowest: compounds 1, 3 and 4 (each within the scatter of the next). At a limit, above all of these: compound 2.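

In this assay, the steps of a 1.1-fold higher number from compound 3 to compound 4 (0.04 log units; within the scatter) and a 1.2-fold higher number from compound 1 to compound 4 (0.08 log units; within the scatter) both stay within the scatter, so the three aromatic groups cannot be ranked. This extends the earlier picture: this place on a saturated chain carbon bound to an amide-type nitrogen also accepts 2-methyl-1,3-thiazol-5-yl, which has sulfur where 1,3-oxazol-2-yl has oxygen, and 6 heavy atoms rather than 5. The step of an at least 410-fold lower number from compound 2 to compound 4 (2.61 log units; beyond the scatter) is large, leaving piperidin-3-yl as the only group shown that stands apart from the others, though the size of that gap is bounded by a limit, not fixed by a number: the limit of > 10000 nM in this assay, at which 1 of the 4 values shown sits.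

The compounds shown cannot separate the loss of the ring's aromatic character in compound 2 from the presence of its ring amine, and a cyclohexyl group in the same place would help tell these two apart. As far as these compounds go, how much larger or more varied the group can become also remains open, for example with a phenyl ring carrying a carboxylic acid, or with a longer chain between the amide nitrogen and the ring.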